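Vinyl to ethyl on the chain at the ring nitrogen

The source may hold more compounds than are shown below. What is called first, only, known or untested is meant among the compounds shown, and "the series" means these compounds.

Series notes. Three compounds carry a value in a functional assay on KB cells (Homo sapiens) for inhibition (a higher number here means a weaker inhibitor, a lower number a stronger inhibitor), and all sit at the weak end of the range. Within the data shown here, compound 1 `NC(=S)c1c(N)n(COCc2ccccc2)c2ncnc(N)c12` gives 225000 nM, the only plain number among the three. Compound 2 `C=CCn1c(N)c(C#N)c2c(N)ncnc21` returns only a limit, > 100000 nM, so no number is known for it in this assay. Compound 3 `N#Cc1c(Br)n(COCc2ccccc2)c2ncnc(N)c12` likewise reaches only a limit, > 100000 nM. Among the measured compounds shown here, compound 2 thus stands at the limit of > 100000 nM in this assay, at which 2 of the 3 values shown sit, with compound 3 beside it and compound 1 the one value read as a number.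

For the measured compounds named here, no pair of the measured compounds differs in a single place, so no measured step within the set is available. The next compound, compound 4 `CCCn1c(N)c(C#N)c2c(N)ncnc21`, differs from compound 2 only by ethyl in place of vinyl on a saturated chain carbon bound to an aromatic nitrogen; seen one bond further out, the change reads allyl to propyl.

Since compound 2 in this assay gives only the limit > 100000 nM, the expectation for compound 4 rests on that limit alone. The step from vinyl to ethyl is expected to produce no change beyond the scatter, so the estimated step that the limit leaves unreadable from compound 2 to compound 4 is close to none. Compound 4 is therefore estimated at 150000 nM in this assay, within 50000 nM to 500000 nM, and most likely it will again be reported only as a limit.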

Compound 4, half-maximal inhibitory concentration: 15000 nM
For compound 4 the middle estimate is 10-fold (1.00 log units) above the measured one; the whole stated range lies above it.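

In this assay, among these compounds, ethyl in place of vinyl on a saturated chain carbon bound to an aromatic nitrogen gives an at least 6.6-fold lower number from compound 2 to compound 4 (0.82 log units; beyond the scatter) and provides the first readable step, as no earlier pair differed in a single place. The two groups have the same count of heavy atoms, and what leaves with vinyl is the double bond outside aromatic rings, so this position responds to a change that small, with compound 4 at 15000 nM as a plain number rather than a limit. The step can be read only as a lower bound, since compound 2 carries only a limit and its true distance from the propyl compound remains unknown: the limit of > 100000 nM in this assay, at which 2 of the 4 values shown sit.

Going by these compounds, whether a longer chain such as butyl, a branched chain such as isopropyl, or a propyl chain ending in an amine would lower the number further remains open. On these data alone, one pair also sets no pattern beyond compound 2 and compound 4, so it is equally open whether saturating the chain would have the same effect on a core carrying the other groups seen in compound 1 and compound 3.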